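The source may hold more compounds than are shown below. What is called first, only, known or untested is meant among the compounds shown, and "the series" means these compounds.

Working notes on the series. In a functional assay on MOLT-4 cells (Homo sapiens) for antiproliferative activity (on this read-out lower numbers stand for stronger inhibition and higher numbers for weaker inhibition), compound 1 `COc1cc(C(=O)c2sc(-c3ccc(C(F)(F)F)cc3)cc2N)cc(OC)c1OC` gives 250 nM, and compound 2 `COc1cc(C(=O)c2sc(-c3cc(OC)c(OC)c(OC)c3)cc2N)cc(OC)c1OC` gives 1200 nM. Among the compounds with values here, compound 1 therefore stands at the lowest of the two numbers recorded, with compound 2 above it by a margin beyond the scatter; no single-point step connects the two, so all that can be read from them is that the ring carrying the trifluoromethyl goes with the lower number. Compound 3 `COc1cc(C(=O)c2sc(-c3ccccc3)cc2N)cc(OC)c1OC` is the next member to be measured in this assay. It differs from compound 1 in one place: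

hydrogen in place of trifluoromethyl on an aromatic carbon

Cut one bond further out, the same difference reads 4-(trifluoromethyl)phenyl to phenyl. Within the data shown here, no measured pair isolates this change, so its size is not known from the data in hand. The expected step from compound 1 to compound 3 is a moderate move toward a higher number, a 2.4-fold higher number from compound 1 to compound 3 (0.38 log units; beyond the scatter), because compound 1 at 250 nM already holds the lowest number seen and the measured pair gives no sign that a smaller group at this position lowers it further. Compound 3 is estimated at 600 nM, with a range from 200 nM to 2000 nM.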

Compound 3, half-maximal inhibitory concentration: 5.3 nM
Compound 3: middle estimate off by 110-fold (2.05 log units), on the high side; the measured number lies below the stated range.
By their numbers in this assay, from the lowest: compound 3; then compound 1; then compound 2.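

In this assay, within the data shown here, the step from trifluoromethyl to hydrogen is large, a 47-fold lower number from compound 1 to compound 3 (1.67 log units; beyond the scatter), and it is the first single-place comparison. It shows that this aromatic carbon, para to a large group, is highly sensitive to substitution and that, of the two groups compared here, hydrogen goes with the much lower number. The earlier comparison of compound 1 with compound 2 involved more than one place and could not isolate this change, so the trifluoromethyl now reads as a group that goes with weaker inhibition relative to hydrogen, and nothing available accounts for the size of the step.

This single pair leaves open whether the higher number of compound 1 is particular to trifluoromethyl or extends to other groups on the same carbon, such as a single fluorine, a methyl or an amine. It also leaves open whether the same change would give a step of similar size on a core differing elsewhere, or in cells other than those of this one read-out.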